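This account rests on a few compounds, and the source may have more. Where it says the series, first, only, none or still open, it means among the compounds named here.

In a functional assay on NCI-H460 cells (Homo sapiens) for cytotoxicity, read by MTT assay, with a stated time of 72 h (a lower number here means a stronger inhibitor, a higher number a weaker inhibitor), compound 2 `CCN(CC)Cc1ccc2nc(NC(=O)N/N=C/c3cn(Cc4ccccc4Cl)c4ccccc34)sc2c1` gives 980 nM and compound 1 `CCN(CC)Cc1ccc2nc(NC(=O)N/N=C/c3cn(Cc4ccc(C(C)(C)C)cc4)c4ccccc34)sc2c1` gives 1670 nM so the two stand within the scatter of each other. Compound 3 `CCN(CC)Cc1ccc2nc(NC(=O)N/N=C/c3cn(Cc4ccc(Cl)c(Cl)c4)c4ccccc34)sc2c1` has not yet been measured. The change from compound 2 is 3,4-dichlorophenyl in place of 2-chlorophenyl on a saturated chain carbon bound to an aromatic nitrogen and it falls on a saturated chain carbon bound to an aromatic nitrogen. Within the data shown here, the only measured step at that place is a 1.7-fold lower number from compound 1 to compound 2 (0.23 log units; within the scatter) and it offers no firm trend, so no step beyond the scatter is expected in this assay in either direction. The estimated step is a 1.1-fold lower number from compound 2 to compound 3 (0.04 log units; within the scatter) and thus stays small. The estimate for compound 3 is 900 nM with 350 nM to 2300 nM as the expected range.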

Compound 3, half-maximal inhibitory concentration: 610 nM
Compound 3: the middle estimate sits 1.5-fold (0.17 log units) above what was measured; measured number inside the range.
By their numbers in this assay, from the lowest: compounds 3, 2 and 1 (each within the scatter of the next, the first and the last beyond it).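

In this assay, 3,4-dichlorophenyl in place of 2-chlorophenyl on a saturated chain carbon bound to an aromatic nitrogen gives a 1.6-fold lower number from compound 2 to compound 3 (0.21 log units; within the scatter), so these two groups cannot be told apart. The same position now also yields its first step beyond the scatter, though a modest one: with 3,4-dichlorophenyl in place of 4-(tert-butyl)phenyl, the result is a 2.7-fold lower number from compound 1 to compound 3 (0.44 log units; beyond the scatter). No measurement offers a reason for either step. On these data alone, it remains open whether that step reflects the added chlorines or the lost tert-butyl group, and how an unsubstituted phenyl, or a phenyl bearing a methoxy group or a carboxylic acid, would compare.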